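The compounds below may be only part of what the source reports. "The series", "measured", "known", "first", "only" and "open" are said of these compounds alone.

In a functional assay on HeLa cells (Homo sapiens) for antiproliferative activity, read by sulforhodamine B assay, with a stated time of 72 h (a higher number here means a weaker inhibitor, a lower number a stronger inhibitor), compound 1 `O=C1CS/C(=N/Nc2nncc3ccccc23)N1c1ccccc1` gives 56 nM, while compound 2 `Cc1cc(C)nc(NS(=O)(=O)c2ccc(Nc3nncc4ccccc34)cc2)n1` gives 3.5 nM. Compound 2 thus has the lower of the two numbers, and the gap lies beyond the usual scatter. Compound 3 `NS(=O)(=O)c1ccc(Nc2nncc3ccccc23)cc1` differs from compound 2 by a single change: hydrogen in place of 4,6-dimethylpyrimidin-2-yl on a sulfonamide nitrogen, with hydrogen in place of 4,6-dimethylpyrimidin-2-yl on a sulfonamide nitrogen. Among the compounds with values here, no measured pair shows this change, so the expectation is loose: a moderate rise in the number, meaning a weaker inhibitor. The expected step is a 5.7-fold higher number from compound 2 to compound 3 (0.76 log units; beyond the scatter). For compound 3 the estimated value is 20 nM, with an expected range of 4 nM to 100 nM.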

Compound 3, half-maximal inhibitory concentration: 12 nM
The estimate for compound 3 lay 1.7-fold (0.22 log units) above the measured number; low and high end bracket the measured number.
By their numbers in this assay, from the lowest: compound 2; then compound 3; then compound 1.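

Replacing 4,6-dimethylpyrimidin-2-yl with hydrogen on the sulfonamide nitrogen gives a 3.4-fold higher number from compound 2 to compound 3 (0.54 log units; beyond the scatter) in this assay. The ring therefore adds to the strength of inhibition at this position, but the step is modest, and compound 3, with its plain sulfonamide, is still a strong inhibitor at 12 nM. Nothing available explains the size of this step. As far as these compounds go, whether a smaller group on that nitrogen, such as methyl, or a simple phenyl ring would recover the number of compound 2 remains open.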